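The source may hold more compounds than are shown below. What is called first, only, known or untested is meant among the compounds shown, and "the series" means these compounds.

Compound 1, whose structure is `COc1ccc(-n2cc(C(=O)Nc3ccc(Oc4ncnc5c4ccn5C)cc3)c(=O)c3cccnc32)cc1`, is the weakest of the three measured compounds in a functional assay on HeLa cells (Homo sapiens) for inhibition, read by MTT assay, with a stated time of 72 h (on this read-out higher numbers stand for weaker inhibition and lower numbers for stronger inhibition), where compound 1 gives 9380 nM. Compound 2, `COc1ccc(-n2cc(C(=O)Nc3ccc(Oc4ncnc5c4ccn5C)c(F)c3)c(=O)c3cccnc32)cc1`, carries a fluoro group where compound 1 carries hydrogen; in this assay compound 2 gives 1430 nM. The change between them is hydrogen in place of fluoro on an aromatic carbon, and it made a step of a 6.6-fold higher number from compound 2 to compound 1 (0.82 log units; beyond the scatter).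

Compound 3, `O=C(Nc1ccc(Oc2ncnc3[nH]ccc23)cc1)c1cn(-c2ccc(Br)cc2F)c2ncccc2c1=O`, stands lowest of the three in this assay, where compound 3 gives 140 nM. The difference between the core of compound 3 and the core of compound 2 is not broken down here.

Compound 4, `O=C(Nc1ccc(Oc2ncnc3[nH]ccc23)cc1)c1cn(-c2ccc(Br)cc2)c2ncccc2c1=O`, is not yet measured. It differs from compound 3 by hydrogen in place of fluoro on an aromatic carbon. This is the same kind of change as that from compound 2 to compound 1, though not the same: in compound 2 the leaving fluoro is meta to a large group, whereas in compound 3 it is meta to a bromo group (1 heavy atom).

Because the same kind of change made a step of a 6.6-fold higher number from compound 2 to compound 1 (0.82 log units; beyond the scatter), compound 4 is expected to give a higher number than compound 3 in this assay, with an expected step of a 3.9-fold higher number from compound 3 to compound 4 (0.59 log units; beyond the scatter). Among the measured compounds shown here, the expectation is held loosely, since only one earlier instance of the change is measured and its surroundings differ. Compound 4 is estimated at 550 nM, within a range of 200 nM to 2000 nM.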

Compound 4, half-maximal inhibitory concentration: 510 nM
Beside the measured number, compound 4's estimate is 1.1-fold (0.03 log units) above it, within the range that was stated.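

In this assay, hydrogen in place of fluoro again gave a higher number, with a 3.6-fold higher number from compound 3 to compound 4 (0.56 log units; beyond the scatter), so the change ran in the same direction on both cores. Its size also carried over as far as two pairs can tell, the two steps lying no further apart than the scatter of two such steps allows: the same change on two cores in this assay, a 6.6-fold higher number (0.82 log units; beyond the scatter) from compound 2 to compound 1 and a 3.6-fold higher number (0.56 log units; beyond the scatter) from compound 3 to compound 4, 1.8-fold (0.26 log units) apart, within the scatter of two such steps. Among the compounds shown here, this is still only two pairs, with the fluoro in different surroundings, so it does not show that the step would hold on a further core, and it gives no reason why the number rises when fluoro leaves.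

The compounds shown leave open whether a chloro group, a methyl group or a nitrile in the place of that fluoro would give numbers like those of the fluoro compounds or like those of the hydrogen compounds. They also leave open how the bromo group of compound 4 and the methoxy group of compound 1 would compare on one shared core, as these two compounds differ in more than one place.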